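Methyl gives way to isopropyl on the shared core

The source may hold more compounds than are shown below. What is called first, only, known or untested is meant among the compounds shown, and "the series" means these compounds.

Compound 1 `Cc1nc2nc(-c3ccccc3)cc(C(F)(F)F)c2c(=O)n1Cc1cn(CCC(F)(F)C(F)(F)C(F)(F)C(F)(F)C(F)(F)C(F)(F)F)nn1`: > 200 ug/mL
Compound 2 `Cc1nc2nc(-c3ccccc3)cc(C(F)(F)F)c2c(=O)n1Cc1cn(CCC(F)(F)C(F)(F)C(F)(F)C(F)(F)C(F)(F)C(F)(F)C(F)(F)C(F)(F)F)nn1`: > 200 ug/mL

Both compounds were tested in a functional assay on THP-1 cells (Homo sapiens) for cytotoxicity, read by MTT assay, with a stated time of 24 h (on this read-out higher numbers stand for weaker inhibition and lower numbers for stronger inhibition), and both results are limits of the assay, not numbers. Compound 2 stands at > 200 ug/mL, which is a limit.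

Compound 3 `CC(C)c1nc2nc(-c3ccccc3)cc(C(F)(F)F)c2c(=O)n1Cc1cn(CCC(F)(F)C(F)(F)C(F)(F)C(F)(F)C(F)(F)C(F)(F)C(F)(F)C(F)(F)F)nn1` departs from compound 2 at a single place: isopropyl in place of methyl on an aromatic carbon. Isopropyl stands in place of methyl on an aromatic carbon, between two ring nitrogen atoms.

For the measured compounds named here, the only measured step is a step that the two limits leave unreadable from compound 1 to compound 2. It puts 1,1,2,2,2-pentafluoroethyl in place of fluoro on a saturated chain carbon, so it does not touch the methyl group and gives no size to carry over. The remaining evidence is the limit of > 200 ug/mL in this assay, at which 2 of the 2 values shown sit. No direction can be read from these data, so no step beyond the scatter is expected in this assay, and compound 3 will most likely report the same limit. The estimated change is a step that the limit leaves unreadable from compound 2 to compound 3. For compound 3 the estimate is 250 ug/mL, with an expected range from 120 ug/mL to 500 ug/mL.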

Compound 3, half-maximal inhibitory concentration: 142 ug/mL
Compound 3: the middle estimate sits 1.8-fold (0.25 log units) above what was measured; the measured number falls inside the stated range.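

In this assay, compound 3 is the first of the compounds shown to give a number instead of a limit, 142 ug/mL, so isopropyl in place of methyl on an aromatic carbon, between two ring nitrogen atoms, brings the read-out within the measurable range. As far as these compounds go, the change is an at least 1.4-fold lower number from compound 2 to compound 3 (0.14 log units; that floor lies within the scatter), so the data cannot separate it from repeat-measurement noise, and its true size stays open on the upper side. The step between the two earlier compounds cannot be read, and the limit still accounts for most of the series: the limit of > 200 ug/mL in this assay, at which 2 of the 3 values shown sit.

From the compounds shown here alone, it remains open whether a larger carbon group such as tert-butyl or cyclohexyl, or an amine or a carboxylic acid, at this same position would move the number further from that limit, or in the other direction. Going by these compounds, it is also open whether isopropyl would give a measurable number with the fluorinated chain of compound 1, so the result rests on one chain and one pair of compounds.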